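A few compounds are considered here, and "the series" means these few. Any claim that something is new, unique, unknown or untested is made for them only; others in the source may bear on it.

Measured in a functional assay on TREX cells for negative allosteric modulation of metabotropic glutamate receptor 3 (Rattus norvegicus), read by calcium flux, with a stated time of 2.5 min; on this read-out lower numbers stand for stronger inhibition and higher numbers for weaker inhibition:
compound 1 `COc1ccc(C#Cc2ccc(C(=O)N3CCC[C@@H](CO)C3)cc2)c(F)c1`: > 10000 nM, a limit of this assay.
compound 2 `COc1ccc(C#Cc2ccc(C(=O)N3CCC[C@@H](CO)C3)cc2)c(F)c1F`: > 10000 nM, likewise a limit.
compound 3 `COc1ccc(C#Cc2ccc(C(=O)N3CCC[C@@H](O)C3)c(F)c2)cc1`: 450 nM; 593 nM; 603 nM (3 entries).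

Within the data shown here, compound 1 stands at the upper limit of this assay; for it only that limit and no number is known. Compound 2, which carries fluoro in place of hydrogen on an aromatic carbon, also stands at the limit, and the step that the two limits leave unreadable from compound 1 to compound 2 cannot be read. Among the measured compounds shown here, compound 3 gives measurable values, (the several entries of compound 3 in this assay, 450 nM; 593 nM; 603 nM (3 entries)), but it differs from compound 1 in more than one place, so no single step joins them; what the two show is only that compound 3 is measurable where compound 1 is not.

Compound 4 `CCOc1ccc(C#Cc2ccc(C(=O)N3CCC[C@@H](CO)C3)cc2)cc1` has not been measured. It differs from compound 1 by 4-ethoxyphenyl in place of 2-fluoro-4-methoxyphenyl on a triple-bonded carbon. For the measured compounds named here, the only measured step that starts from compound 1 is the one to compound 2, and that step is unreadable; no measured step touches an ethoxy group at all. With the limit of > 10000 nM in this assay, at which 2 of the 3 values shown sit, the series as seen gives no ground for a readable gain from compound 1.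

Compound 4 is therefore expected to remain near the limit, with an estimated value of 8000 nM in this assay, in a range of 1500 nM to 30000 nM. The expected step of an at least 1.2-fold lower number from compound 1 to compound 4 (0.09 log units; that floor lies within the scatter) is accordingly small and may again be masked by a limit.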

Compound 4, half-maximal inhibitory concentration: > 10000 nM
Compound 4: no number, only a limit; the forecaster's own chance of this, stated with the estimate: 55%; middle value at least 1.2-fold (0.09 log units) away from the limit.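

In this assay compound 4 gives > 10000 nM, a limit and not a number, as does compound 1 with its own limit, so the step between compound 1 and compound 4 cannot be read. Left open is whether 4-ethoxyphenyl in place of 2-fluoro-4-methoxyphenyl changes inhibition at all on the core of compound 1.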